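Swapping iodo for fluoro on a thiosemicarbazone series

This account rests on a few compounds, and the source may have more. Where it says the series, first, only, none or still open, it means among the compounds named here.

Values measured in a functional assay on U-87MG ATCC cells (Homo sapiens) for cytotoxicity, read by MTT assay, with a stated time of 48 h (on this read-out higher numbers stand for weaker inhibition and lower numbers for stronger inhibition), are these
compound 1 `C/C(=N\NC(=S)Nc1ccc(I)cc1)c1ccccn1` gives 59 nM
compound 2 `C/C(=N\NC(=S)Nc1cccc(F)c1)c1ccccn1` gives 18 nM
compound 3 `C/C(=N/NC(=S)Nc1ccccc1)c1ccccn1` gives 1.4 nM

Compound 1 has the highest number of the three and so the weakest inhibition, beyond the scatter from both others. The step to compound 4 `C/C(=N\NC(=S)Nc1ccc(F)cc1)c1ccccn1` is fluoro in place of iodo on an aromatic carbon and amounts to fluoro in place of iodo on an aromatic carbon, para to a large group. Among the compounds with values here, no measured pair isolates this change. Compound 2 also carries fluoro and gives 18 nM in a lower position than compound 1, so a moderate fall beyond the scatter is expected in this assay for this change. The expected shift is a 3.9-fold lower number from compound 1 to compound 4 (0.59 log units; beyond the scatter) as an estimate only. Compound 4 is estimated at 15 nM with an expected range from 3 nM to 60 nM in a single measurement.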

Compound 4, half-maximal inhibitory concentration: 10 nM
The estimate for compound 4 lay 1.5-fold (0.18 log units) above the measured number, within the range that was stated.
By their numbers in this assay, from the lowest: compound 3; then compounds 4 and 2 (each within the scatter of the next); then compound 1.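

In this assay, fluoro in place of iodo on an aromatic carbon, para to a large group, gives a 5.9-fold lower number from compound 1 to compound 4 (0.77 log units; beyond the scatter) and so puts a first direct size on this change, a modest one beyond the scatter. Within the data shown here, none of the earlier compounds differed from another in one place alone, so this is the first reading that isolates a single group at this carbon. Nothing available accounts for the shift.

Still open, going by these compounds, is how chloro, bromo, methoxy or an amine at this same carbon would read on the shared core.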